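The source may report more compounds than this note shows. Statements on the series, on what has been measured and on what is new or still open speak of the compounds shown alone.

Measured compounds:
- compound 1, `CCN(CC)c1ccc(N2C(=O)NC3(CSC4=C3C(=O)c3ncccc3C4=O)C2=O)cc1`, gives 960 nM in a functional assay on SF-268 cells (Homo sapiens) for antiproliferative activity, read by MTT assay, with a stated time of 96 h; on this read-out higher numbers stand for weaker inhibition and lower numbers for stronger inhibition
- compound 2, `O=C1C2=C(C(=O)c3ncccc31)C1(CS2)NC(=O)N(c2ccncc2)C1=O`, gives 1100 nM in this assay

Among the compounds with values here, only two compounds have been measured, and they share one core, differing only in the group on an amide-type nitrogen in a ring. Compound 2 sits at the top of this short list on paper, but its distance from compound 1 lies within the scatter of repeated measurements, so the two cannot be told apart on these numbers. Within the data shown here, no step between them is reported as meaningful.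

Compound 3, `CC(C)(C)c1ccc(N2C(=O)NC3(CSC4=C3C(=O)c3ncccc3C4=O)C2=O)cc1`, has not yet been measured. It differs from compound 2 in one place: 4-(tert-butyl)phenyl in place of pyridin-4-yl on an amide-type nitrogen in a ring. Among the measured compounds shown here, the change brings a group that, like the one in compound 1, is a six-membered carbon ring carrying a single substituent, whereas the group that leaves carries a ring nitrogen.

For the measured compounds named here, with only two measured compounds, both within scatter of each other, there is no basis for expecting a large step in this assay in either direction. Compound 3 is expected to give a number close to those already seen, with a step from a 1.2-fold lower number from compound 2 to compound 3 (0.09 log units; within the scatter) that is expected to stay within the scatter. The estimate for compound 3 is 900 nM, with a range from 300 nM to 3000 nM.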

Compound 3, half-maximal inhibitory concentration: 500 nM
Compound 3: the middle estimate sits 1.8-fold (0.26 log units) above what was measured; the measured number falls inside the stated range.
By their numbers in this assay, from the lowest: compounds 3, 1 and 2 (each within the scatter of the next, the first and the last beyond it).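

In this assay, the group on the amide-type nitrogen in a ring now gives a step that stands clear of the usual scatter: 4-(tert-butyl)phenyl in place of pyridin-4-yl gives a 2.2-fold lower number from compound 2 to compound 3 (0.34 log units; beyond the scatter), a modest change and the first at this position that can be read as real. With the six-membered ring of carbon only kept in place, tert-butyl in place of diethylamino on an aromatic carbon gives a 1.9-fold lower number from compound 1 to compound 3 (0.28 log units; within the scatter), which lies within the scatter, so these two substituents cannot be told apart on these numbers. Nothing measured here says what lies behind either step.

An unsubstituted phenyl group, with neither a ring nitrogen nor a substituent, stands outside the compounds shown, so it remains open how much of the step to compound 3 goes with losing the ring nitrogen and how much goes with gaining tert-butyl. Also open, as far as these compounds go, is how a carboxylic acid, a methoxy group or a longer alkyl chain in place of tert-butyl on that aromatic carbon would read in this assay.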